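This account rests on a few compounds, and the source may have more. Where it says the series, first, only, none or still open, it means among the compounds named here.

Of the compounds shown here, three sharing one core have been tested in an ADME assay on L02 cells (Homo sapiens) for cytotoxicity, read by MTT assay, with a stated time of 48 h; on this read-out higher numbers stand for weaker inhibition and lower numbers for stronger inhibition. Compound 1 `O=c1[nH]c2ccccc2cc1-c1nc2cc(Br)ccc2[nH]1` reaches in this assay only the limit > 100000 nM, which is a limit of the assay and not a number. Compound 2 `Cc1ccc2[nH]c(=O)c(-c3nc4ccccc4[nH]3)cc2c1` gives in this assay likewise only the limit > 100000 nM. Compound 3 `COc1ccc2[nH]c(=O)c(-c3nc4ccccc4[nH]3)cc2c1` stops in this assay also at the limit > 100000 nM. The step that the two limits leave unreadable from compound 2 to compound 3, methoxy in place of methyl on an aromatic carbon, cannot therefore be read. Compound 2 thus stands at a limit, as do the two other values, all sitting at the limit of > 100000 nM in this assay, at which 3 of the 3 values shown sit. Compound 4 `Cc1ccc2[nH]c(=O)c(-c3nc4cc(Br)ccc4[nH]3)cc2c1` differs from compound 2 by bromo in place of hydrogen on an aromatic carbon. Among the measured compounds shown here, no measured step bears directly on this change; the only guide is that every value shown sits at the limit of > 100000 nM in this assay, at which 3 of the 3 values shown sit. In this assay the expected step is a step that the limit leaves unreadable from compound 2 to compound 4, none beyond the scatter. Compound 4 is therefore estimated at 150000 nM, within 50000 nM to 500000 nM, and is expected most likely to be reported again as a limit.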

Compound 4, half-maximal inhibitory concentration: > 100000 nM
Compound 4: no number, only a limit; the forecaster's own chance of this, stated with the estimate: 85%; the middle value lies beyond the limit too.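

Compound 4 gives only a limit, so the steps to it from compound 1 and from compound 2 cannot be read: (the limit of > 100000 nM in this assay, at which 4 of the 4 values shown sit). The compounds shown leave open whether any change to the shared core would give a readable value in this assay and how large such a step would be.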